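A few compounds are considered here, and "the series" means these few. Any claim that something is new, unique, unknown or untested is made for them only; others in the source may bear on it.

In a functional assay on HCT-116 cells (Homo sapiens) for inhibition, read by MTT assay, with a stated time of 72 h (a higher number here means a weaker inhibitor, a lower number a stronger inhibitor), compound 1 `COc1cc2c(Oc3ccc(NC(=O)c4nn(-c5ccccc5C)cc(C)c4=O)cc3)ccnc2cc1OCCCCCC(=O)NO` gives 290 nM and compound 2 `COc1cc2c(Oc3ccc(NC(=O)c4nn(-c5ccccc5C)cc(C)c4=O)cc3)ccnc2cc1OCCCCCCC(=O)NO` gives 660 nM while compound 3 `COc1cc2c(Oc3ccc(NC(=O)c4nn(-c5ccccc5C)cc(C)c4=O)c(F)c3)ccnc2cc1OCCCCCCC(=O)NO` gives 2300 nM as the highest of the three numbers. Compound 4 `COc1cc2c(Oc3ccc(NC(=O)c4nn(-c5ccccc5C)ccc4=O)c(F)c3)ccnc2cc1OCCCCCCC(=O)NO` follows from compound 3 by one change hydrogen in place of methyl on an aromatic carbon with hydrogen in place of methyl on an aromatic carbon. Within the data shown here, no measured step touches this place. The chain step a 2.3-fold higher number from compound 1 to compound 2 (0.36 log units; beyond the scatter) and the fluoro step a 3.5-fold higher number from compound 2 to compound 3 (0.54 log units; beyond the scatter) are both modest and serve only as a guide to size. What is therefore expected in this assay is a 1.2-fold lower number from compound 3 to compound 4 (0.08 log units; within the scatter) with no firm direction and nothing larger than those modest steps. Compound 4 is estimated at 1900 nM with an expected range from 800 nM to 4500 nM in this read-out.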

Compound 4, half-maximal inhibitory concentration: 4390 nM
The estimate for compound 4 lay 2.3-fold (0.36 log units) below the measured number; the measured number falls inside the stated range.
By their numbers in this assay, from the lowest: compound 1; then compound 2; then compounds 3 and 4 (each within the scatter of the next).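

In this assay, among these compounds, hydrogen in place of methyl on the aromatic carbon opposite the ring nitrogen gives a 1.9-fold higher number from compound 3 to compound 4 (0.28 log units; within the scatter), the only reading at this position. Unlike the chain and fluoro steps, this step stays within the scatter, so the methyl is not shown to matter here, at least with the fluoro present. Nothing measured bears on the reason for this.

From the compounds shown here alone, whether ethyl, methoxy or an amine at this carbon would separate from methyl and hydrogen remains open. So does whether the same change behaves alike on compound 2, which lacks the fluoro.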